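From hydroxy to a substituted amino group

This account rests on a few compounds, and the source may have more. Where it says the series, first, only, none or still open, it means among the compounds named here.

Compound 1 `CCC(CC)(c1ccc(OCC(=O)C(C)(C)C)c(C)c1)c1ccc(N(CC(=O)C(C)(C)C)Cc2ccccc2)c(C)c1`: > 100000 nM (a limit)
Compound 2 `CCC(CC)(c1ccc(O)c(C)c1)c1ccc(OCC(=O)C(C)(C)C)c(C)c1`: 5230 nM

Of the compounds shown here, two have been measured in an ADME assay on MDBK cells (Bos taurus) for cytotoxicity; a lower number here means that less compound is tolerated, a higher number that more compound is tolerated. Going by the values given here, compound 2 holds the only actual number, 5230 nM. Compound 1 gives only a limit of the assay, > 100000 nM. Among the compounds with values here, no measured step links the two.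

Compound 3 `CCC(CC)(c1ccc(NCC(=O)C(C)(C)C)c(C)c1)c1ccc(OCC(=O)C(C)(C)C)c(C)c1` departs from compound 2 by one change on an aromatic carbon: (((tert-butyl)carbonyl)methyl)amino in place of hydroxy, ((((tert-butyl)carbonyl)methyl)amino in place of hydroxy on an aromatic carbon). Within the data shown here, the one measured compound with a substituted amino group is compound 1, at > 100000 nM, so a rise beyond the scatter is expected, though a single example is thin support. The expected change is estimated as a 5.7-fold higher number from compound 2 to compound 3 (0.76 log units; beyond the scatter). For compound 3 the estimated value is 30000 nM, with an expected range of 8000 nM to 100000 nM.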

Compound 3, half-maximal cytotoxic concentration: 82000 nM
The estimate for compound 3 lay 2.7-fold (0.44 log units) below the measured number, and the stated range covers the measured number.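

In this assay, the change at this aromatic carbon now has a direct reading: (((tert-butyl)carbonyl)methyl)amino in place of hydroxy gives a 16-fold higher number from compound 2 to compound 3 (1.20 log units; beyond the scatter). Compound 3 reaches this high number with a hydrogen on the nitrogen, so the benzyl group of compound 1 is not required for it. Hydrogen in place of benzyl gives an at least 1.2-fold lower number from compound 1 to compound 3 (0.08 log units; that floor lies within the scatter), but compound 1 holds only a limit, so this step sets a floor and its true size stays unknown: the limit of > 100000 nM in this assay, at which 1 of the 3 values shown sits.

Going by these compounds, what remains open is whether the rise follows from the nitrogen or from the chain it carries, which a plain amino group or the same chain joined through an oxygen atom would separate. A smaller chain on the nitrogen, such as methyl or acetyl, would show how much of the added group the rise requires.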